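The compounds below may be only part of what the source reports. "The series", "measured", "known", "first", "only" and "open" are said of these compounds alone.

Measured so far:
Compound 1, `COc1cc(OC)c(C(=O)/C=C/c2ccc(Cl)cc2)c(OC)c1`, gives 1.5%.
Compound 2, `COc1cccc(/C=C/C(=O)c2c(O)cc(OC)cc2OC)c1`, gives 34%.

In a functional assay on Caco-2 cells (Homo sapiens), read by fluorescence and BrdU incorporation, with a stated time of 48 h, tested at 25 uM (a lower number here means a stronger effect, a higher number a weaker effect of the compound at the concentration tested), compound 1 stands at the lowest of the two numbers shown. Compound 2, the nearest of the two, gives 34%, a number well beyond the scatter above compound 1; no single-point comparison between the two is drawn here, since they differ in more than one place.

Compound 3, `COc1cc(OC)c(C(=O)/C=C/c2ccc(F)cc2)c(OC)c1`, has not yet been measured in this assay. It differs from compound 1 in one place only: fluoro in place of chloro on an aromatic carbon. The shared core is kept entire, and the change is a swap of one halogen for another on the ring that carries it.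

On the numbers shown, compound 1 already sits close to the floor of this assay, so the room for a stronger effect is small. A step from compound 1 to compound 3 is expected to be modest and upward, to a weaker effect, and it may well stay within the usual scatter; the step expected is a number 6.5 percentage points higher from compound 1 to compound 3 (within the scatter). Compound 3 is therefore estimated at 8%, within a range from 1% to 30%.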

Compound 3, a percentage reported as activity, at one concentration (the size of the read-out at that concentration, not a potency): 13%
Beside the measured number, compound 3's estimate is 5 percentage points below it; the range from low to high includes it.
By their numbers in this assay, from the lowest: compound 1; then compound 3; then compound 2.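

In this assay, among these compounds, the change from 4-chlorophenyl to 4-fluorophenyl gives the one step in this set that can be read at a single place, a step of a number 11.5 percentage points higher from compound 1 to compound 3 (beyond the scatter) and one that is modest in size. It shows that this position, on an aromatic carbon para to a large group, is not indifferent to which of these two halogens it carries: with the shared core kept entire, the swap alone moves the read-out, and chloro goes with the lower number and so the stronger effect. Nothing measured here accounts for this step.

Going by these compounds, with only chloro and fluoro read at this position, it stays open whether the read-out follows any order among groups placed there, which bromo, methoxy, trifluoromethyl or an amine at the same carbon would begin to settle. On these data alone, it also stays open whether the same swap of halogens would give a step of like size on a core carrying other groups, such as a hydroxy group in place of a methoxy group.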